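A few compounds are considered here, and "the series" means these few. Any claim that something is new, unique, unknown or untested is made for them only; others in the source may bear on it.

Measured compounds in a functional assay on RAW264.7 cells (Mus musculus) for inhibition, read by Griess assay, with a stated time of 18 h; a lower number here means a stronger inhibitor, a higher number a weaker inhibitor:
compound 1 `CC(=O)O[C@H](C[C@@H](O)C[C@H](O)/C=C/c1ccccc1)C[C@H]1CC=CC(=O)O1`, reported only as a limit: > 50000 nM
compound 2 `O=C1C=CC[C@H](C[C@H](O)C[C@@H](O)C[C@H](O)/C=C/c2ccccc2)O1`: 3200 nM

Going by the values given here, compound 2 stands as the only number in this assay; the value of compound 1 is a limit (the limit of > 50000 nM in this assay, at which 1 of the 2 values shown sits). Among the compounds with values here, the single measured step is an at least 15-fold lower number from compound 1 to compound 2 (1.19 log units; beyond the scatter), a change at the acetylated oxygen. Compound 3 `O=C1C=C[C@H](O)[C@H](C[C@H](O)C[C@@H](O)C[C@H](O)/C=C/c2ccccc2)O1` differs from compound 2 by hydroxy in place of hydrogen on a saturated ring carbon. Within the data shown here, no measured step touches a hydroxy on a ring carbon, so no step beyond the scatter is expected in this assay, a 1.1-fold lower number from compound 2 to compound 3 (0.03 log units; within the scatter). Compound 3 is therefore estimated at 3000 nM, between 1000 nM and 10000 nM.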

Compound 3, half-maximal inhibitory concentration: 13800 nM
Estimate against measurement, compound 3: 4.6-fold (0.66 log units) below; the whole stated range lies below it.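

The position on the saturated ring carbon, next to the ring atom that bears a large group, is sensitive to substitution: hydroxy in place of hydrogen brings a 4.3-fold higher number from compound 2 to compound 3 (0.63 log units; beyond the scatter) in this assay. A free hydroxy therefore does not go with a lower number everywhere, since the free chain hydroxy of compound 2 goes with a lower number than the acetylated oxygen of compound 1. Nothing shown here gives a cause for the ring step.

Open, on these data alone, is whether a methoxy, an acetoxy or an amine on this ring carbon would follow the hydroxy. As far as these compounds go, the effect of the opposite configuration at this carbon also remains open.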